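A few compounds are considered here, and "the series" means these few. Any claim that something is new, unique, unknown or untested is made for them only; others in the source may bear on it.

Compound 1 `CN(C(=O)NC(=O)c1c(F)cccc1F)c1nc(C(F)(F)F)c(C(=O)N/N=C/c2cccc(C(F)(F)F)c2)s1` was tested in a functional assay on MCF7 cells (Homo sapiens) for inhibition, read by MTT assay, with a stated time of 72 h (a higher number here means a weaker inhibitor, a lower number a stronger inhibitor), and gave 21.8 ug/mL. Among the compounds that return a number in this assay, compound 1 stands lowest, and its nearest neighbour is compound 2 `Cc1nc(N(C)C(=O)NC(=O)c2c(F)cccc2F)sc1C(=O)N/N=C/c1cccc(C(F)(F)F)c1`, which in this assay gives 28.2 ug/mL; the only single-point step measured here, a 1.3-fold higher number from compound 1 to compound 2 (0.11 log units; within the scatter), lies within the scatter. Compound 3 `CNc1nc(C(F)(F)F)c(C(=O)N/N=C/c2cccc(C(F)(F)F)c2)s1` reaches only a limit of this assay, > 100 ug/mL. That one of the three values sits at the limit of > 100 ug/mL in this assay, at which 1 of the 3 values shown sits, is all this assay says of compound 3.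

Compound 4 `CN(C(=O)NC(=O)c1ccc(F)c(F)c1)c1nc(C(F)(F)F)c(C(=O)N/N=C/c2cccc(C(F)(F)F)c2)s1` differs from compound 1 in one place: 3,4-difluorophenyl in place of 2,6-difluorophenyl on a carbonyl carbon. For the measured compounds named here, no measured step touches this part of the structure; the one step that was measured, at an aromatic carbon of the shared core, stayed within the scatter and bears on the difluorophenyl change only by showing that the core tolerates a small swap. With nothing pointing either way, compound 4 is expected to move no further than the scatter from compound 1, an expected step of a 1.2-fold higher number from compound 1 to compound 4 (0.08 log units; within the scatter). The estimate for compound 4 in this assay is therefore 26 ug/mL, with a range from 11 ug/mL to 65 ug/mL.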

Compound 4, half-maximal inhibitory concentration: 4.15 ug/mL
Compound 4: the middle estimate sits 6.3-fold (0.80 log units) above what was measured; measured number outside the range, below it.
By their numbers in this assay, from the lowest: compound 4; then compounds 1 and 2 (each within the scatter of the next). At a limit, above all of these: compound 3.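

In this assay, the change from 2,6-difluorophenyl to 3,4-difluorophenyl on the carbonyl carbon gives a 5.3-fold lower number from compound 1 to compound 4 (0.72 log units; beyond the scatter), the first step shown that goes beyond the scatter. For the compounds shown here, the two groups hold the same atoms, joined differently, so this part of the structure, which no earlier step touched, responds to where the two fluorines stand, whereas the earlier swap of methyl for trifluoromethyl on the shared core did not move the number beyond the scatter. Nothing at hand gives a reason for this step.

On these data alone, whether the step comes from fluorine at the new places or from its loss at the old ones stays open, and plain phenyl, 4-fluorophenyl or 3,4-dichlorophenyl on this carbonyl carbon would help to separate the two. Also open, as far as these compounds go, is whether 3,4-difluorophenyl has the same effect on compound 2, which carries methyl in place of trifluoromethyl.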